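A smaller amino group on the shared core

A few compounds are considered here, and "the series" means these few. Any claim that something is new, unique, unknown or untested is made for them only; others in the source may bear on it.

Compound 1 `[O-][n+]1nc(NCc2ccccc2)[n+]([O-])c2ccccc21`: 2200 nM
Compound 2 `CCCCCCCCNc1n[n+]([O-])c2ccccc2[n+]1[O-]`: 4900 nM
Compound 3 `CCN(CC)c1n[n+]([O-])c2ccccc2[n+]1[O-]`: > 17600 nM

These compounds share one core and differ in the amino group. In a functional assay on MOLT-4 cells (Homo sapiens) for cytotoxicity, read by MTT assay, with a stated time of 48 h (a higher number here means a weaker inhibitor, a lower number a stronger inhibitor), compound 3 gives > 17600 nM, which is a limit and not a number. Compound 4 `C=CCNc1n[n+]([O-])c2ccccc2[n+]1[O-]` changes that group: allylamino in place of diethylamino on an aromatic carbon.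

For the measured compounds named here, the one measured step, a 2.2-fold higher number from compound 1 to compound 2 (0.35 log units; beyond the scatter), is modest. It joins two compounds that, like compound 4, keep a hydrogen on the amino nitrogen, which compound 3 lacks. Compound 4 is therefore expected to resemble compound 1 at 2200 nM and compound 2 at 4900 nM, giving a lower number in this assay. The expected change is an at least 2.9-fold lower number from compound 3 to compound 4 (0.46 log units; beyond the scatter). The estimate for compound 4 is 6000 nM, with an expected range from 2500 nM to 15000 nM.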

Compound 4, half-maximal inhibitory concentration: 3000 nM
Compound 4: middle estimate off by 2.0-fold (0.30 log units), on the high side, and the stated range covers the measured number.
By their numbers in this assay, from the lowest: compounds 1, 4 and 2 (each within the scatter of the next, the first and the last beyond it). At a limit, above all of these: compound 3.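

For the compounds shown here, replacing diethylamino with allylamino on this aromatic carbon gives an at least 5.8-fold lower number from compound 3 to compound 4 (0.76 log units; beyond the scatter), the first step here from an amino group with no hydrogen-bond donor to one with a donor. That step is only a minimum, since compound 3 stands at a limit of the assay: the limit of > 17600 nM in this assay, at which 1 of the 4 values shown sits. Vinyl in place of heptyl gives a 1.6-fold lower number from compound 2 to compound 4 (0.21 log units; within the scatter), and vinyl in place of phenyl gives a 1.4-fold higher number from compound 1 to compound 4 (0.13 log units; within the scatter), so the small allylamino group fits in with the larger groups on the shared core.

Still open, from the compounds shown here alone, is whether the lost donor or the second ethyl chain sets compound 3 apart. Ethylamino and dimethylamino on the same carbon would separate the two.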